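A few compounds are considered here, and "the series" means these few. Any claim that something is new, unique, unknown or untested is made for them only; others in the source may bear on it.

In a functional assay on L1210 cells (Mus musculus) for antiproliferative activity (a lower number here means a stronger inhibitor, a higher number a weaker inhibitor), compound 1 `COc1cc(C(=O)c2sc(-c3ccc([N+](=O)[O-])cc3)cc2N)cc(OC)c1OC` gives 100 nM and compound 2 `COc1cc(C(=O)c2sc(-c3ccc(I)cc3)cc2N)cc(OC)c1OC` gives 400 nM as the higher of the two numbers, which makes it the weaker inhibitor of the pair. Compound 3 `COc1cc(C(=O)c2sc(-c3ccncc3)cc2N)cc(OC)c1OC` has pyridin-4-yl in place of 4-iodophenyl on an aromatic carbon and has no number yet. Going by the values given here, the one measured step that bears on this change is a 4.0-fold higher number from compound 1 to compound 2 (0.60 log units; beyond the scatter) for iodo in place of nitro on an aromatic carbon. That step is modest but beyond the scatter. It exchanges a group on the aromatic ring, whereas compound 3 exchanges the ring itself, so the guidance is indirect. Among the compounds with values here, no measured compound carries pyridin-4-yl, and the data do not fix the direction. A step no larger than the measured one is expected in this assay, leaning towards a higher number. The expected change is a 1.8-fold higher number from compound 2 to compound 3 (0.24 log units; within the scatter) as a working estimate. For compound 3 the estimated value is 700 nM with an expected range from 150 nM to 3000 nM at this stage.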

Compound 3, half-maximal inhibitory concentration: 1810 nM
Compound 3: the middle estimate sits 2.6-fold (0.41 log units) below what was measured, within the range that was stated.
By their numbers in this assay, from the lowest: compound 1; then compound 2; then compound 3.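

Working notes on the series: in this assay, the place next to the ring sulfur responds to an exchange of the whole aromatic ring and not only to an exchange of the group on that ring, with a 4.5-fold higher number from compound 2 to compound 3 (0.66 log units; beyond the scatter) as the step for pyridin-4-yl in place of 4-iodophenyl. The same ring exchange measured against the 4-nitrophenyl compound gives an 18-fold higher number from compound 1 to compound 3 (1.26 log units; beyond the scatter), a large step that makes compound 3 the weakest inhibitor of the three and shows that the choice of ring at this place can shift the number far more than the iodo-for-nitro change did. Nothing in hand accounts for these differences.

Compound 3 differs from compound 2 both by carrying a ring nitrogen and by lacking a ring substituent, so the contribution of each remains unseparated, and an unsubstituted phenyl or a pyridin-3-yl group would bear on that question. On these data alone, it also remains open how a phenyl ring carrying an amine, a carboxylic acid or a nitrile at this place would compare with the 4-nitrophenyl group of compound 1.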